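Fluoro for methoxy on the phenol ring in a second core

This account rests on a few compounds, and the source may have more. Where it says the series, first, only, none or still open, it means among the compounds named here.

Compound 1 `COc1ccc(OC)c(/C=C/C(=O)C(=Cc2ccc(O)c(OC)c2)C(=O)/C=C/c2cc(OC)ccc2OC)c1` and compound 2 `COc1ccc(OC)c(/C=C/C(=O)C(=Cc2ccc(O)c(F)c2)C(=O)/C=C/c2cc(OC)ccc2OC)c1` share one core and differ at one place: fluoro in place of methoxy on an aromatic carbon. In a functional assay on A549 cells (Homo sapiens) for antiproliferative activity, read by sulforhodamine B assay, with a stated time of 48 h (a lower number here means a stronger inhibitor, a higher number a weaker inhibitor), compound 1 gives 190 nM and compound 2 gives 220 nM, so the change made a 1.2-fold higher number from compound 1 to compound 2 (0.06 log units; within the scatter). Compound 3 `COc1ccc(/C=C/C(=O)C(=Cc2ccc(O)c(OC)c2)C(=O)/C=C/c2ccc(OC)cc2OC)c(OC)c1` carries the same atoms as compound 1, joined differently; the difference between the two cores is not broken down here. In this assay compound 3 gives 590 nM, beyond the scatter from both compound 1 and compound 2. Compound 4 `COc1ccc(/C=C/C(=O)C(=Cc2ccc(O)c(F)c2)C(=O)/C=C/c2ccc(OC)cc2OC)c(OC)c1` is not yet measured; it differs from compound 3 by fluoro in place of methoxy on an aromatic carbon, the same change as in the first pair. Within the data shown here, for compound 4 a step of about a 1.2-fold higher number from compound 3 to compound 4 (0.06 log units; within the scatter) in this assay is expected, resting on the single earlier step of a 1.2-fold higher number from compound 1 to compound 2 (0.06 log units; within the scatter) applied to compound 3. Compound 4 is thus estimated at 680 nM, between 350 nM and 1400 nM.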

Compound 4, half-maximal inhibitory concentration: 2070 nM
Compound 4: middle estimate off by 3.0-fold (0.48 log units), on the low side; measured number outside the range, above it.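

In this assay, the change from 4-hydroxy-3-methoxyphenyl to 3-fluoro-4-hydroxyphenyl does not transfer unchanged between the two cores: the same change on two cores in this assay, a 1.2-fold higher number (0.06 log units; within the scatter) from compound 1 to compound 2 and a 3.5-fold higher number (0.55 log units; beyond the scatter) from compound 3 to compound 4, 3.0-fold (0.48 log units) apart, beyond the scatter of two such steps. On the core of compound 3 the change weakens activity, with a 3.5-fold higher number from compound 3 to compound 4 (0.55 log units; beyond the scatter), so the near-neutral step on the core of compound 1 is not a reliable guide for that core. These two pairs show that the size of the step differs with the core, but not why it differs or how the change would behave on any further core.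

As far as these compounds go, it remains open whether the same core dependence would appear with other groups in this place, such as chloro, ethoxy or an amine. A third core carrying the same change would show whether either step is typical.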